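This account rests on a few compounds, and the source may have more. Where it says the series, first, only, none or still open, it means among the compounds named here.

In a functional assay on SF-268 cells (Homo sapiens) for inhibition, read by sulforhodamine B assay, with a stated time of 48 h, tested at 100 uM (on this read-out lower numbers stand for a stronger effect and higher numbers for a weaker effect at the one concentration tested), compound 2 `COc1cc(Cl)cc(-c2nn(-c3cccc(NC(=O)Nc4ccc(Cl)c(C(F)(F)F)c4)c3)cc2-c2ccncc2)c1` gives -58%, the lowest of the two numbers recorded, and compound 1 `O=C(Nc1cccc(-n2cc(-c3ccncc3)c(-c3cc(O)cc(Cl)c3)n2)c1)Nc1ccc(Cl)c(Cl)c1` gives -11%, a reading that sits far above it, beyond the usual scatter. Compound 3 `COc1cc(Cl)cc(-c2nn(-c3cccc(NC(=O)Nc4ccc(Cl)c(Cl)c4)c3)cc2-c2ccncc2)c1` is the next member and has not yet been measured in this assay. It differs from compound 2 by one change: chloro in place of trifluoromethyl on an aromatic carbon. Among the compounds with values here, with no measured pair sharing this change, the step expected from this one difference is modest, a number 13 percentage points higher from compound 2 to compound 3 (beyond the scatter), towards a weaker effect. Compound 3 is therefore estimated at -45%, with a range from -65% to -15%.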

Compound 3, a percentage reported as activity, at one concentration (the size of the read-out at that concentration, not a potency): 11%
Compound 3: middle estimate off by 56 percentage points, on the low side; measured number outside the range, above it.
By their numbers in this assay, from the lowest: compound 2; then compound 1; then compound 3.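

In this assay, the change from 4-chloro-3-(trifluoromethyl)phenyl to 3,4-dichlorophenyl gives a large step, a number 69 percentage points higher from compound 2 to compound 3 (beyond the scatter), so in this pair the effect depends strongly on which of these two groups the position carries. Methyl in place of hydrogen on an oxygen on an aromatic ring gives a modest step, a number 22 percentage points higher from compound 1 to compound 3 (beyond the scatter), also towards a weaker effect. Nothing measured here accounts for either step.

From the compounds shown here alone, how a nitrile, an amine or a methoxy group at this position would read remains open. So does the size of the oxygen step when trifluoromethyl stands in place of chloro.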